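A few compounds are considered here, and "the series" means these few. Any claim that something is new, unique, unknown or untested is made for them only; others in the source may bear on it.

Of the compounds shown here, three sharing one core have been measured in a functional assay on A-375 cells (Homo sapiens) for antiproliferative activity, read by MTT assay, with a stated time of 24 h, tested at 100 ug/mL; a higher number here means a stronger effect of the compound at the concentration tested, a lower number a weaker effect. Compound 1 `Cc1ccc2nc(C(=O)Nc3c(F)cc(-c4cccc(F)c4)cc3F)c(C)c(O)c2c1` gives 56.4%, the highest of the three numbers. Compound 2 `CCc1ccc2nc(C(=O)Nc3c(F)cc(-c4cccc(F)c4)cc3F)c(C)c(O)c2c1` gives 47.3%, and compound 3 `Cc1c(C(=O)Nc2c(F)cc(-c3cccc(F)c3)cc2F)nc2ccc(OC(F)(F)F)cc2c1O` gives 25.6%. The step of a number 9.1 percentage points lower from compound 1 to compound 2 (within the scatter) lies within the scatter, whereas the steps of a number 30.8 percentage points lower from compound 1 to compound 3 (beyond the scatter) and a number 21.7 percentage points lower from compound 2 to compound 3 (beyond the scatter) lie beyond it. All three of these steps concern a group on an aromatic carbon of the core; none of them touches the hydroxy group. Compound 4 `Cc1ccc2nc(C(=O)Nc3c(F)cc(-c4cccc(F)c4)cc3F)c(C)c(C(=O)O)c2c1` differs from compound 1 as follows: carboxy in place of hydroxy on an aromatic carbon. Among the compounds with values here, no measured step bears on this change, so there is nothing among the measured compounds from which its size or direction can be read, and the wide swing seen from compound 1 to compound 3 shows that a single change on this core can move the read-out a long way. The expected outcome for compound 4 in this assay is therefore set wide: an estimate of 35% with a range from 10% to 65%. This estimate means an expected step of a number 21.4 percentage points lower from compound 1 to compound 4 (beyond the scatter).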

Compound 4, a percentage reported as inhibition, at one concentration (the size of the read-out at that concentration, not a potency): 37.3%
Compound 4: the middle estimate sits 2.3 percentage points below what was measured, and the stated range covers the measured number.
By their numbers in this assay, from the lowest: compound 3; then compounds 4, 2 and 1 (each within the scatter of the next, the first and the last beyond it).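

Moving to the position opposite the ring nitrogen, which the earlier steps left untouched, shows that this site also affects the read-out in this assay: carboxy in place of hydroxy gives a result a number 19.1 percentage points lower from compound 1 to compound 4 (beyond the scatter). The step arises although hydroxy and carboxy are counted with the same hydrogen-bond donor and acceptor and neither carries a net charge; what differs in the count is 1 heavy atom leaving and 3 heavy atoms entering. No measurement at hand explains the step.

The compounds shown leave open how a methoxy group, an amine, a methyl ester or a primary amide would fare at this position. They also leave open whether carboxy in place of hydroxy would give a similar step with ethyl or trifluoromethoxy in place of the methyl group on the other ring.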